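Phosphorus configuration and aryl swap in a prodrug series

The compounds below may be only part of what the source reports. "The series", "measured", "known", "first", "only" and "open" are said of these compounds alone.

Measured compounds:
compound 1 `COC(=O)CCNC(=O)[C@@H]1O[P@@](=O)(OCOC(=O)c2ccnn2C)OCC1(C)C`: > 1 h
compound 2 `COC(=O)CCNC(=O)[C@@H]1O[P@](=O)(OCOC(=O)c2scnc2C)OCC1(C)C`: < 0.16 h
compound 3 `COC(=O)CCNC(=O)[C@@H]1O[P@@](=O)(OCOC(=O)c2scnc2C)OCC1(C)C`: > 1 h

In an ADME assay on blood (Homo sapiens) for pharmacokinetics (a lower number here means that the compound disappears faster, a higher number that the compound lasts longer), compound 2 gives < 0.16 h, which is a limit of the assay and not a number. Compound 1 gives > 1 h, also a limit. Compound 3 gives > 1 h, again a limit. Compound 4 `CCc1cc(C(=O)OCO[P@]2(=O)OCC(C)(C)[C@H](C(=O)NCCC(=O)OC)O2)n(C)n1` is not yet measured. It differs from compound 2 as follows: 3-ethyl-1-methyl-1H-pyrazol-5-yl in place of 4-methyl-1,3-thiazol-5-yl on a carbonyl carbon. Within the data shown here, two measured steps bear on it. The step that the two limits leave unreadable from compound 1 to compound 3 shows that the aryl swap within the other phosphorus configuration cannot be read because of the limit of < 0.16 h in this assay, at which 1 of the 3 values shown sits, and (the limit of > 1 h in this assay, at which 2 of the 3 values shown sit). The step of an at least 6.2-fold higher number from compound 2 to compound 3 (0.79 log units; beyond the scatter) shows that the configuration drawn at phosphorus matters because of the fact that compounds 2 and 3 differ only in the configuration as drawn. Compound 4 keeps the configuration of compound 2, so compound 4 is expected to stay short-lived, with a step that the limit leaves unreadable from compound 2 to compound 4, estimated at 0.1 h (range 0.03 h to 0.4 h).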

Compound 4, half-life: < 0.16 h
Compound 4 was reported as a limit (the forecaster's own chance of this, stated with the estimate: 70%); the middle value is on the limit's open side.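

The step from compound 2 to compound 4 cannot be read, because both compounds sit at the same limit: the limit of < 0.16 h in this assay, at which 2 of the 4 values shown sit. The compounds shown leave open whether 3-ethyl-1-methyl-1H-pyrazol-5-yl and 4-methyl-1,3-thiazol-5-yl differ in half-life at either phosphorus configuration.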